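Five-membered ring variation on the imidazoline ether core

The source may hold more compounds than are shown below. What is called first, only, known or untested is meant among the compounds shown, and "the series" means these compounds.

The series shares the core of compound 3 `c1c[nH]c(-c2ccccc2OCC2=NCCN2)c1`, in which a five-membered aromatic ring sits on the six-membered carbon ring. Among the compounds with values here, in a functional assay for activation of Alpha-1B adrenergic receptor (Homo sapiens), read by calcium flux (on this read-out higher numbers stand for an effect only at larger amounts of compound and lower numbers for an effect already at smaller amounts), compound 3 gives 1 nM, the lowest of the two numbers known so far. Compound 2 `c1coc(-c2ccccc2OCC2=NCCN2)c1` gives 10 nM. Compound 1 `Cc1cccnc1-c1ccccc1OCC1=NCCN1` reaches only a limit of the assay, < 100000 nM, and yields no number. Within the data shown here, the one measured step between compounds that differ in a single place is a 10-fold lower number from compound 2 to compound 3 (1.00 log units; beyond the scatter).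

Compound 4 `Cn1nccc1-c1ccccc1OCC1=NCCN1` is not yet measured. From compound 3 it changes as follows: 1-methyl-1H-pyrazol-5-yl in place of 1H-pyrrol-2-yl on an aromatic carbon. Among the measured compounds shown here, the only measured step that bears on this is a 10-fold lower number from compound 2 to compound 3 (1.00 log units; beyond the scatter), where the ring carrying a hydrogen-bond donor gave the lower number. For the measured compounds named here, compound 4 gives up that donor and takes on a ring with two hydrogen-bond acceptors, a direction for which no measured step exists in this set, so the uncertainty is wide. The expected step is therefore toward a higher number, a 30-fold higher number from compound 3 to compound 4 (1.48 log units; beyond the scatter), rather than none beyond the scatter. Compound 4 is estimated at 30 nM, in the range 5 nM to 300 nM.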

Compound 4, half-maximal effective concentration: < 100000 nM
Compound 4: a limit, no number; the forecaster's own chance of this, stated with the estimate: 5%; the middle value lies beyond the limit too.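

In this assay compound 4 stands at a limit of the assay and yields no number: the limit of < 100000 nM in this assay, at which 2 of the 4 values shown sit. The steps from compound 3 and from compound 2 to compound 4 therefore cannot be read. The compounds shown leave open which part of the change to 1-methyl-1H-pyrazol-5-yl, the second ring nitrogen or the methyl, goes with this limit.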